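From isopropyl to tert-butyl on a fatty acid receptor agonist

The source may report more compounds than this note shows. Statements on the series, on what has been measured and on what is new or still open speak of the compounds shown alone.

compound 1 `O=C(O)COc1ccc(NC(=O)COc2ccccc2)cc1F` — "not determined" (no result reported) in a functional assay on CHO cells for agonist activity at Free fatty acid receptor 1 (Homo sapiens), read by FLIPR; on this read-out lower numbers stand for an effect already at smaller amounts and higher numbers for an effect only at larger amounts of compound
compound 2 `Cc1cccc(OCC(=O)Nc2ccc(OCC(=O)O)c(F)c2)c1` — 108 nM
compound 3 `CC(C)c1cccc(OCC(=O)Nc2ccc(OCC(=O)O)c(F)c2)c1` — 116 nM

Compound 3 stands at the highest of the two numbers, yet its gap to compound 2 lies within the scatter, so the two cannot be separated. Compound 4 `CC(C)(C)c1cccc(OCC(=O)Nc2ccc(OCC(=O)O)c(F)c2)c1` differs from compound 3 by methyl in place of hydrogen on a saturated chain carbon bound to an aromatic carbon and two saturated chain carbons. Among the measured compounds shown here, the single measured step that bears on this change is a 1.1-fold higher number from compound 2 to compound 3 (0.03 log units; within the scatter), which stayed within the scatter. On that basis the account expects no step beyond the scatter in this assay, as expressed by a 1.1-fold higher number from compound 3 to compound 4 (0.05 log units; within the scatter). For compound 4 the estimated value is 130 nM, with an expected range from 50 nM to 350 nM.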

Compound 4, half-maximal effective concentration: 122 nM
The estimate for compound 4 lay 1.1-fold (0.03 log units) above the measured number; low and high end bracket the measured number.
By their numbers in this assay, from the lowest: compounds 2, 3 and 4 (each within the scatter of the next).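

In this assay, tert-butyl on this aromatic carbon stays level with both smaller groups: a 1.1-fold higher number from compound 3 to compound 4 (0.02 log units; within the scatter), and a 1.1-fold higher number from compound 2 to compound 4 (0.05 log units; within the scatter). Adding methyl to the saturated chain carbon of isopropyl therefore leaves the number within the scatter, and methyl, isopropyl and tert-butyl cannot be told apart here. No evidence is available to explain this flat run.

From the compounds shown here alone, whether an amine, a carboxylic acid or a methoxy group at this place would behave alike remains open. Compound 1 gives "not determined" (no result reported), so the step from hydrogen to methyl cannot be read.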